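Swapping a pyridine ring for a hydroxyphenyl ring

This account rests on a few compounds, and the source may have more. Where it says the series, first, only, none or still open, it means among the compounds named here.

Measured in a functional assay on HCT-15 cells (Homo sapiens) for cytotoxicity, read by ELISA, with a stated time of 2 days; a lower number here means a stronger inhibitor, a higher number a weaker inhibitor:
Compound 1 `Oc1ccc(-c2cc(-c3ccccc3)cc(-c3ccccc3)n2)cc1`: 3700 nM
Compound 2 `Oc1ccc(-c2cc(-c3ccccc3)cc(-c3cccnc3)n2)cc1`: 15100 nM

Compound 2 has the higher number of the two, which makes it the weaker inhibitor in this assay. Compound 3 `Oc1ccc(-c2cc(-c3ccccc3)cc(-c3ccc(O)cc3)n2)cc1` carries 4-hydroxyphenyl in place of pyridin-3-yl on an aromatic carbon. Within the data shown here, only one measured step bears on this: a 4.1-fold higher number from compound 1 to compound 2 (0.61 log units; beyond the scatter), which came with pyridin-3-yl in place of phenyl. Among the measured compounds shown here, compound 3 again has a ring of carbon only at that place, but no measured compound shows what 4-hydroxyphenyl does there. A modest move to a lower number is therefore expected, of similar or smaller size. The expected change is a 2.5-fold lower number from compound 2 to compound 3 (0.40 log units; beyond the scatter). For compound 3 the estimated value is 6000 nM, with an expected range of 2000 nM to 18000 nM.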

Compound 3, half-maximal inhibitory concentration: 3000 nM
For compound 3 the middle estimate is 2.0-fold (0.30 log units) above the measured one; the measured number falls inside the stated range.
By their numbers in this assay, from the lowest: compounds 3 and 1 (each within the scatter of the next); then compound 2.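

At the ring carbon next to the ring nitrogen, 4-hydroxyphenyl in place of pyridin-3-yl gives a 5.0-fold lower number from compound 2 to compound 3 (0.70 log units; beyond the scatter) in this assay. Hydroxy in place of hydrogen on the phenyl ring of compound 1 gives a 1.2-fold lower number from compound 1 to compound 3 (0.09 log units; within the scatter), so the rings of carbon only in compound 1 and compound 3 cannot be told apart here, and compound 2 alone stands apart. No measurement at hand explains these differences.

From the compounds shown here alone, whether a methoxy group or an amine in place of that hydroxy would give a similar number stays open. So does whether pyridin-4-yl at this carbon would match pyridin-3-yl.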